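From 4-bromophenyl to 3,4-dichlorophenyl on a shared core

The compounds below may be only part of what the source reports. "The series", "measured", "known", "first", "only" and "open" are said of these compounds alone.

In a functional assay on MOLT-4 cells (Homo sapiens) (a lower number here means a stronger inhibitor, a higher number a weaker inhibitor), compound 1 `Cc1ccc(/C=C/C(=O)Oc2ccc(/C=C3\CCCCC3=O)cc2)cc1` gives 156000 nM while compound 2 `O=C(/C=C/c1ccc(Br)cc1)Oc1ccc(/C=C2\CCCCC2=O)cc1` gives 180000 nM and so stands level with it. For the measured compounds named here, the one measured step, bromo in place of methyl on an aromatic carbon, is a 1.2-fold higher number from compound 1 to compound 2 (0.06 log units; within the scatter) and is the only guide here. Compound 3 `O=C(/C=C/c1ccc(Cl)c(Cl)c1)Oc1ccc(/C=C2\CCCCC2=O)cc1` brings 3,4-dichlorophenyl in place of 4-bromophenyl on a double-bonded chain carbon bound to a double-bonded chain carbon with 3,4-dichlorophenyl in place of 4-bromophenyl on a double-bonded chain carbon bound to a double-bonded chain carbon. Because a 1.2-fold higher number from compound 1 to compound 2 (0.06 log units; within the scatter) stayed small, the expected 1.2-fold lower number from compound 2 to compound 3 (0.08 log units; within the scatter) means no shift beyond the scatter in this assay in either direction. The estimate for compound 3 is 150000 nM within an expected range (70000 nM to 300000 nM).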

Compound 3, half-maximal inhibitory concentration: 47300 nM
For compound 3 the middle estimate is 3.2-fold (0.50 log units) above the measured one; the measured number lies below the stated range.
By their numbers in this assay, from the lowest: compound 3; then compounds 1 and 2 (each within the scatter of the next).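

At this place, on a double-bonded chain carbon bound to a double-bonded chain carbon, the choice of aryl group does register in this assay: 3,4-dichlorophenyl in place of 4-bromophenyl gives a 3.8-fold lower number from compound 2 to compound 3 (0.58 log units; beyond the scatter), and in place of 4-methylphenyl it gives a 3.3-fold lower number from compound 1 to compound 3 (0.52 log units; beyond the scatter). For the compounds shown here, compound 1 and compound 2 had stood level, leaving this as the first change to pass the scatter. Nothing available accounts for the shift. Still open, from the compounds shown here alone, is whether 4-chlorophenyl, with its single chlorine, would read like compound 3 or like compound 2, and how an amine or a carboxylic acid on that phenyl ring would read.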